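Hydroxy in place of hydrogen on compound 2, expectation

The source may hold more compounds than are shown below. What is called first, only, known or untested is meant among the compounds shown, and "the series" means these compounds.

Compound 1 `N#Cc1cc(NCc2ccccc2[N+](=O)[O-])c2cn[nH]c2c1` gives 7% in an assay for inhibition of Indoleamine 2,3-dioxygenase 1 (Homo sapiens), with stated times of 10 min and 60 min, tested at 10 uM; a lower number here means a weaker effect, a higher number a stronger effect of the compound at the concentration tested. Compound 2 `O=[N+]([O-])c1ccccc1CNc1cc(Br)cc2[nH]ncc12` gives 67% in this assay, a step of a number 60 percentage points higher from compound 1 to compound 2 (beyond the scatter). On these two numbers compound 2 stands highest, with compound 1 the nearest and its value lying beyond the scatter below.

Compound 3 `O=[N+]([O-])c1ccc(O)cc1CNc1cc(Br)cc2[nH]ncc12` has yet to be measured in this assay. It differs from compound 2 by hydroxy in place of hydrogen on an aromatic carbon. Going by the values given here, the single measured step, a number 60 percentage points higher from compound 1 to compound 2 (beyond the scatter), concerns a different place on the shared core and a different exchange of groups, so it does not bear on this change. Among the compounds with values here, no measured pair shows what hydroxy in place of hydrogen does here. The expectation is therefore a step of a number 7 percentage points lower from compound 2 to compound 3 (within the scatter) in this assay, nothing beyond the scatter, with a wide range for the lack of any guiding step. Compound 3 is estimated at 60%, between 30% and 85%.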

Compound 3, a percentage reported as inhibition, at one concentration (the size of the read-out at that concentration, not a potency): 92%
Compound 3: middle estimate off by 32 percentage points, on the low side, and the stated range ends below it.
By their numbers in this assay, from the lowest: compound 1; then compound 2; then compound 3.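

The aromatic carbon para to the nitro group is a place where substitution can raise the read-out: hydroxy in place of hydrogen there brings a number 25 percentage points higher from compound 2 to compound 3 (beyond the scatter) in this assay. Going by these compounds alone, the earlier pair covered only bromo in place of cyano at another place on the shared core, so this is the first measured change on the ring that carries the nitro group. Nothing available accounts for the gain.

As far as these compounds go, whether it is specific to hydroxy stays open, since a methoxy group, an amine or a carboxylic acid on the same carbon would each test a different replacement. Also open, from the compounds shown here alone, is whether the same change would raise the read-out with cyano in place of bromo, as on compound 1.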